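Methyl in place of hydrogen on the shared core

A few compounds are considered here, and "the series" means these few. Any claim that something is new, unique, unknown or untested is made for them only; others in the source may bear on it.

Compound 2 `COc1ccc(C[S+]([O-])c2ncccc2C(=O)Nc2ccncc2)c(OC)c1` sits at the floor of the numbers shown: in an ADME assay (on this read-out higher numbers stand for a longer-lived compound and lower numbers for a shorter-lived compound), compound 2 gives < 0.02 h, which is a limit of the assay rather than a number (the limit of < 0.02 h in this assay, at which 1 of the 2 values shown sits). Compound 3 `COc1cc(C)c(C[S+]([O-])c2ncccc2C(=O)Nc2ccncc2)c(OC)c1` carries the change (methyl in place of hydrogen on an aromatic carbon). Among the compounds with values here, the only measured step that bears on it is the one from compound 1 `COc1cc(OC)c(C[S+]([O-])c2ncccc2C(=O)Nc2ccncc2)cc1Br`, where in this assay compound 1 gives 0.07 h, and an at least 3.5-fold lower number from compound 1 to compound 2 (0.54 log units; beyond the scatter). A substituent entering the ring in place of hydrogen is therefore expected to raise the number, by an at least 2.0-fold higher number from compound 2 to compound 3 (0.30 log units; that floor lies within the scatter). Compound 3 is thus estimated at 0.04 h, between 0.01 h and 0.15 h.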

Compound 3, half-life: < 0.02 h
Compound 3: a limit, no number (the forecaster's own chance of this, stated with the estimate: 35%); middle value at least 2.0-fold (0.30 log units) from the limit.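

In this assay compound 3 gives < 0.02 h, a limit of the assay and not a number. Within the data shown here, compound 2 stands at the same limit, so no step between compound 2 and compound 3 can be read. As far as these compounds go, whether methyl in place of hydrogen on an aromatic carbon changes the half-life at all stays open.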